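This account rests on a few compounds, and the source may have more. Where it says the series, first, only, none or still open, it means among the compounds named here.

Three analogues sharing one core have been measured in an ADME assay on BJ cells (Homo sapiens), read by MTT assay, with a stated time of 72 h; on this read-out higher numbers stand for weaker inhibition and lower numbers for stronger inhibition. Compound 1 `COc1ncnc2c1c(-c1cccs1)cn2[C@@H]1O[C@H](CO)[C@@H](O)[C@H]1O` gives 62800 nM, compound 2 `C#Cc1cn([C@@H]2O[C@H](CO)[C@@H](O)[C@H]2O)c2ncnc(OC)c12` gives 98400 nM, and compound 3 `COc1ncnc2c1c(I)cn2[C@@H]1O[C@H](CO)[C@@H](O)[C@H]1O` gives 91000 nM, which places compound 3 second highest of the three numbers, nearest compound 2 and furthest from compound 1, with both gaps within the scatter. Compound 4 `COc1ncnc2c1c(-c1cc3ccccc3o1)cn2[C@@H]1O[C@H](CO)[C@@H](O)[C@H]1O` differs from compound 3 by 1-benzofuran-2-yl in place of iodo on an aromatic carbon. The step that bears on this most runs the other way, a 1.4-fold higher number from compound 1 to compound 3 (0.16 log units; within the scatter), where thiophen-2-yl gave way to iodo; a 1.1-fold lower number from compound 2 to compound 3 (0.03 log units; within the scatter) adds little. Because a 1.4-fold higher number from compound 1 to compound 3 (0.16 log units; within the scatter) stayed within the scatter, compound 4 is expected to show no step beyond the scatter, a 1.5-fold lower number from compound 3 to compound 4 (0.18 log units; within the scatter), with an estimated value of 60000 nM in a range from 20000 nM to 150000 nM.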

Compound 4, half-maximal inhibitory concentration: 22400 nM
Estimate against measurement, compound 4: 2.7-fold (0.43 log units) above, and the stated range covers the measured number.
By their numbers in this assay, from the lowest: compound 4; then compounds 1, 3 and 2 (each within the scatter of the next).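

At this aromatic carbon of the shared core, swaps among thiophen-2-yl, ethynyl and iodo stayed within the scatter, but 1-benzofuran-2-yl moves the number beyond it against iodo (a 4.1-fold lower number from compound 3 to compound 4 (0.61 log units; beyond the scatter)), against ethynyl (a 4.4-fold lower number from compound 2 to compound 4 (0.64 log units; beyond the scatter)) and against thiophen-2-yl (a 2.8-fold lower number from compound 1 to compound 4 (0.45 log units; beyond the scatter)). The position therefore does respond to a change of group in this assay, and compound 4 stands lowest of the four. Nothing available explains this step. On these data alone, it remains open whether the six-membered aromatic ring of carbon only is needed for the step, and how an amine or a carboxylic acid at this carbon would read.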